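The source may hold more compounds than are shown below. What is called first, only, known or untested is meant among the compounds shown, and "the series" means these compounds.

Series notes, compound 1 to compound 4. Compound 1 `CNC(=O)N1CCCc2ccc(NC(=O)c3cccc(-c4ccn(C(C)=O)n4)c3)cc21` is the reference point; in a functional assay on MV4-11 cells (Homo sapiens) for antiproliferative activity, with a stated time of 6 days, tested at 6.25 uM (a higher number here means a stronger effect of the compound at the concentration tested, a lower number a weaker effect), compound 1 gives 87.6%, the highest of the three numbers in hand. Compound 2 `CNC(=O)N1CCCc2ccc(NC(=O)c3ccc(-c4ccccc4)cc3)cc21` is nearest to it, and in this assay compound 2 gives 74.3%, which lies beyond the scatter below compound 1. Compound 3 `CNC(=O)N1CCCc2ccc(NC(=O)c3ccc(-c4cnn(S(C)(=O)=O)c4)cc3)cc21` is furthest off; in this assay compound 3 gives 40.2%. Compound 4 `CNC(=O)N1CCCc2ccc(NC(=O)c3cccc(-c4cnn(C)c4)c3)cc21` has not yet been measured. It differs from compound 1 in one place: 1-methyl-1H-pyrazol-4-yl in place of 1-acetyl-1H-pyrazol-3-yl on an aromatic carbon. Among the compounds with values here, only one measured single-point step exists among the three compounds, and it bears on the change loosely at best: it is a number 34.1 percentage points lower from compound 2 to compound 3 (beyond the scatter), where a substituted pyrazolyl displaced a phenyl, whereas here one substituted pyrazolyl displaces another. That step shows a large movement of this read-out when the group at this position changes, so a downward step beyond the scatter in this assay is taken as the more likely outcome, though of smaller size than the measured one. For compound 4 the expected step is a number 15.6 percentage points lower from compound 1 to compound 4 (beyond the scatter). Compound 4 is estimated at 72% in this assay, within a range of 45% to 92%.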

Compound 4, a percentage reported as inhibition, at one concentration (the size of the read-out at that concentration, not a potency): 93.5%
Beside the measured number, compound 4's estimate is 21.5 percentage points below it; the measured number lies above the stated range.
By their numbers in this assay, from the lowest: compound 3; then compound 2; then compounds 1 and 4 (each within the scatter of the next).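

In this assay, replacing 1-acetyl-1H-pyrazol-3-yl with 1-methyl-1H-pyrazol-4-yl on this aromatic carbon gives a number 5.9 percentage points higher from compound 1 to compound 4 (within the scatter), so the acetyl group and its carbonyl are not needed to keep the read-out at the single concentration tested. The large movement seen when phenyl left in a number 34.1 percentage points lower from compound 2 to compound 3 (beyond the scatter) therefore does not carry over to this exchange of one substituted pyrazolyl for another, and this position, meta to a large group, tolerates the smaller of the two groups without a change beyond the scatter. No available evidence explains why the read-out holds across this change.

The exchange alters both the substituent on the pyrazole and the point of attachment, so the compounds shown leave open what each alteration contributes alone, and a single-concentration read-out may hide a difference in potency between compound 1 and compound 4. They also leave open how far this tolerance extends, for example whether a longer chain such as 2-(dimethylamino)ethyl or a group bearing a carboxylic acid, in place of the methyl of 1-methyl-1H-pyrazol-4-yl, would keep the read-out.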